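Swapping Fluoro for Methyl on the Aryl Ether

The source may hold more compounds than are shown below. What is called first, only, known or untested is meant among the compounds shown, and "the series" means these compounds.

Of the compounds shown here, three sharing one core have been measured in a physicochemical assay for lipophilicity, in phosphate buffer, measured as octanol-water partition; a lower number here means a more polar compound, a higher number a more lipophilic compound. Compound 1 `Cc1nc2ccccc2c(=O)n1/N=C/c1ccc(Oc2ccc(Cl)cc2)cc1` gives 4.6. Compound 2 `Cc1nc2ccccc2c(=O)n1/N=C/c1ccc(Oc2ccc3ccccc3c2)cc1` gives 5.22 in this assay, and the step of a number 0.62 log units higher from compound 1 to compound 2 (beyond the scatter) is the largest rise among the measured pairs. Compound 3 `Cc1nc2ccccc2c(=O)n1/N=C/c1ccc(Oc2ccc(F)cc2)cc1` gives 4.21 in this assay, the lowest of the three numbers: the step of a number 0.39 log units lower from compound 1 to compound 3 (beyond the scatter) separates it from compound 1, and the step of a number 1.01 log units lower from compound 2 to compound 3 (beyond the scatter) from compound 2.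

Compound 4 `Cc1ccc(Oc2ccc(/C=N/n3c(C)nc4ccccc4c3=O)cc2)cc1` is the next compound of this series, differing from compound 3 in one place: methyl in place of fluoro on an aromatic carbon. Going by the values given here, of the measured steps, only the step of a number 0.39 log units lower from compound 1 to compound 3 (beyond the scatter) touches the same aromatic carbon, and it exchanges one halogen for another. Among the compounds with values here, no measured step puts a methyl in place of a halogen, so the direction rests on that single halogen comparison and on the general tendency of a methyl to count as at least as lipophilic as a fluoro.

Compound 4 is therefore expected to come out modestly higher than compound 3 in this assay, with an estimate of 4.55 and a likely range from 4.2 to 4.9. The expected step of a number 0.34 log units higher from compound 3 to compound 4 (beyond the scatter) would be beyond the scatter but smaller than the rise to compound 2.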

Compound 4, partition coefficient: 4.32
For compound 4 the middle estimate is 0.23 log units above the measured one; measured number inside the range.
By their numbers in this assay, from the lowest: compounds 3, 4 and 1 (each within the scatter of the next, the first and the last beyond it); then compound 2.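

In this assay, the step of a number 0.11 log units higher from compound 3 to compound 4 (within the scatter) shows that methyl in place of fluoro on this aromatic carbon, para to a large group, leaves the two compounds unresolved. The step of a number 0.28 log units lower from compound 1 to compound 4 (within the scatter) shows the same for methyl in place of chloro, although the two halogen compounds are themselves separated by the step of a number 0.39 log units lower from compound 1 to compound 3 (beyond the scatter), so methyl cannot be assigned a clear rank against either halogen. Exchanging the whole aryl group still gives a clear difference, as the step of a number 0.90 log units lower from compound 2 to compound 4 (beyond the scatter) shows for 4-methylphenyl in place of naphthalen-2-yl, but no measurement offered here explains any of these numbers.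

The compounds shown leave open whether a longer chain such as ethyl or propyl on the same aromatic carbon would move the number beyond the scatter from the methyl of compound 4. They also leave open how far an amine or a carboxylic acid at that carbon would shift the partition coefficient, since all the groups compared here are halogens, methyl or the fused aromatic naphthalen-2-yl.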